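Aryl to arylpropyl exchange on the ring amine nitrogen

The source may hold more compounds than are shown below. What is called first, only, known or untested is meant among the compounds shown, and "the series" means these compounds.

Two compounds of the series are measured. Compound 1 `Nc1scc(CN2CCN(c3ccc(Cl)cc3F)CC2)c1C(=O)c1ccc(Cl)cc1` gives 1% in an assay on CHO cells for displacement of a labelled ligand from adenosine receptor A3 (Homo sapiens), read by scintillation counting, with a stated time of 120 min, tested at 10 uM (a higher number here means more inhibition at the concentration tested (going by the name of the read-out), a lower number less inhibition), and compound 2 `Nc1scc(CN2CCN(c3ccc(F)c(Cl)c3)CC2)c1C(=O)c1ccc(Cl)cc1` gives 0%. Among the measured compounds shown here, the only measured step, a number 1 percentage points lower from compound 1 to compound 2 (within the scatter), leaves the two values within the scatter of each other, so compound 2 stands alongside compound 1, both showing essentially no displacement at the tested concentration.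

Compound 3 `Nc1scc(CN2CCN(CCCc3ccc(Cl)cc3)CC2)c1C(=O)c1ccc(Cl)cc1` is not yet measured. It differs from compound 2 in one place: 3-(4-chlorophenyl)propyl in place of 3-chloro-4-fluorophenyl on an amine nitrogen in a ring. For the measured compounds named here, no measured step puts 3-(4-chlorophenyl)propyl or any chain on this nitrogen; the one known step, 3-chloro-4-fluorophenyl for 4-chloro-2-fluorophenyl, stayed within the scatter. With both measured values near zero, compound 3 is expected to give 5% in this assay, in the range -10% to 25%. The step of a number 5 percentage points higher from compound 2 to compound 3 (within the scatter) this estimate implies is expected to be none beyond the scatter.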

Compound 3, a percentage reported as inhibition, at one concentration (the size of the read-out at that concentration, not a potency): 0%
Compound 3: middle estimate off by 5 percentage points, on the high side; low and high end bracket the measured number.
By their numbers in this assay, from the lowest: compounds 2, 3 and 1 (each within the scatter of the next).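

In this assay, placing 3-(4-chlorophenyl)propyl on the amine nitrogen in a ring gives no change at the digits printed from compound 2 to compound 3 (within the scatter) and a number 1 percentage points lower from compound 1 to compound 3 (within the scatter) as the two readings against the directly attached halophenyl groups. The earlier compounds shown here varied only the halogen pattern on a phenyl group at this nitrogen; this result extends the flat reading to a propyl chain carrying the aromatic ring, with 10 heavy atoms entering where 8 left. No supporting data bear on why the reading stays flat at this position.

All compounds shown sit within the scatter of one another, so none identifies a change at this nitrogen that moves the number. From the compounds shown here alone, whether a longer chain, an amide or a carboxylic acid here would give measurable displacement remains open, as does any change elsewhere on the shared core.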